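Adding a Chloro Group to the Phenyl Ring of Compound 3

This account rests on a few compounds, and the source may have more. Where it says the series, first, only, none or still open, it means among the compounds named here.

The measured compounds, all tested in a functional assay on U-87MG ATCC cells for antiproliferative activity against U-87 MG (Homo sapiens), read by MTT assay, with a stated time of 48 h, tested at 100 uM; a higher number here means a weaker effect of the compound at the concentration tested, a lower number a stronger effect:
compound 1, `Cc1nc(-c2ccc(Cl)cc2)sc1C(=O)CSc1nc(-c2ccc(Cl)c(Cl)c2)c(C#N)c(=O)[nH]1`, gives 36.5%;
compound 2, `COc1ccc(-c2nc(SCC(=O)c3sc(-c4ccc(Cl)cc4)nc3C)[nH]c(=O)c2C#N)cc1OC`, gives 18.7%;
compound 3, `COc1cccc(-c2nc(SCC(=O)c3sc(-c4ccccc4)nc3C)[nH]c(=O)c2C#N)c1`, gives 21.8%.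

Compound 3 lies within the usual scatter of compound 2, so the two cannot be told apart on these numbers, while compound 1 stands beyond the scatter above both, meaning a weaker effect at the tested concentration. For the measured compounds named here, the only measured step, a number 17.8 percentage points lower from compound 1 to compound 2 (beyond the scatter), concerns the aryl group on the other end of the shared core and so does not touch the part that changes here.

Compound 4, `COc1cccc(-c2nc(SCC(=O)c3sc(-c4ccc(Cl)cc4)nc3C)[nH]c(=O)c2C#N)c1`, differs from compound 3 by chloro in place of hydrogen on an aromatic carbon. Going by the values given here, no measured pair shows this change, so there is no direct guide to its size. As far as these compounds go, the values of compounds 2 and 3 show that a change on the far aryl group left the read-out nearly unchanged; what a chloro on this phenyl does is unknown. The expectation is therefore a step of about a number 2.2 percentage points higher from compound 3 to compound 4 (within the scatter) in this assay, that is, no step beyond the scatter in either direction. Compound 4 is estimated at 24%, with a range from 12% to 40%.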

Compound 4, a percentage reported as activity, at one concentration (the size of the read-out at that concentration, not a potency): 8.54%
Compound 4: the middle estimate sits 15.5 percentage points above what was measured, outside the stated range (below it).
By their numbers in this assay, from the lowest: compound 4; then compounds 2 and 3 (each within the scatter of the next); then compound 1.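

Chloro in place of hydrogen, which turns phenyl into 4-chlorophenyl para to a large group, gives a number 13.3 percentage points lower from compound 3 to compound 4 (beyond the scatter) in this assay, the first sign that this position on the phenyl can shift the read-out beyond the scatter. With the 4-chlorophenyl in place, the aryl group at the other end also counts: hydrogen in place of methoxy gives a number 10.2 percentage points lower from compound 2 to compound 4 (beyond the scatter), and 3-methoxyphenyl in place of 3,4-dichlorophenyl gives a number 28 percentage points lower from compound 1 to compound 4 (beyond the scatter), which leaves compound 4 with the strongest effect of the four at the tested concentration. Nothing measured here explains why this single added atom lowers the number.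

The compounds shown leave open whether a bromo or an amine at this same position would lower the number as chloro does, or whether the effect belongs to chloro alone. They also leave open whether the step from hydrogen to chloro keeps its size with another aryl group at the far end, such as 3,4-dimethoxyphenyl, since the pair shown carries only 3-methoxyphenyl there.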